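This account rests on a few compounds, and the source may have more. Where it says the series, first, only, none or still open, it means among the compounds named here.

Measured so far:
Compound 1 `Cc1nc(-c2ccccc2NCC2=NCCN2)co1`: in a functional assay for activation of Alpha-1D adrenergic receptor (Homo sapiens) (a lower number here means that less compound is needed, a higher number that more compound is needed for the effect), compound 1 gives only a limit, < 5020 nM.
Compound 2 `c1ccc(-c2cnoc2)c(NCC2=NCCN2)c1`: in this assay compound 2 also gives only a limit, < 100000 nM.
Compound 3 `Cc1nc(-c2ccccc2NCC2=NCCN2)no1`: in this assay compound 3 likewise gives only a limit, < 5020 nM.

Compound 3 thus stands at the limit of < 5020 nM in this assay, at which 2 of the 3 values shown sit, which it shares with compound 1, while compound 2 sits at the limit of < 100000 nM in this assay, at which 1 of the 3 values shown sits. Compound 4 `CC/C(=N\OC)c1ccccc1NCC1=NCCN1` differs from compound 3 by a group of 6 heavy atoms (4 carbon, 1 nitrogen, 1 oxygen; no ring) in place of a group of 6 heavy atoms (3 carbon, 2 nitrogen, 1 oxygen; one five-membered aromatic ring with 3 hetero atoms), on an aromatic carbon. Among the measured compounds shown here, the measured steps a step that the two limits leave unreadable from compound 1 to compound 3 and a step that the two limits leave unreadable from compound 2 to compound 3 cannot be read in size, and a step that the two limits leave unreadable from compound 1 to compound 2 is no more readable, so no measured step tells how large the change to compound 4 should be or in which direction. Compound 4 is therefore expected near the same region, estimated at 3000 nM, between 300 nM and 30000 nM. The step that the limit leaves unreadable from compound 3 to compound 4 is expected as a rough guess only.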

Compound 4, half-maximal effective concentration: < 100000 nM
Compound 4: a limit, no number; the forecaster's own chance of this, stated with the estimate: 40%; the middle value lies beyond the limit too.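

Compound 4 gives only a limit, as do compound 1, compound 2 and compound 3, so none of its steps from those three compounds can be read in size. On these data alone, how strongly any of these four compounds acts in this assay, and which needs the least, stays open.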